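Chlorine for oxygen on the fused core: expected cytotoxicity

A few compounds are considered here, and "the series" means these few. Any claim that something is new, unique, unknown or untested is made for them only; others in the source may bear on it.

Measured compounds:
compound 1, `COc1c(/C=C2/C(=O)Nc3ccc(Cl)cc32)c2ccccc2n1-c1ccccc1`, 2340 nM
compound 2, `COc1cc2c(/C=C3/C(=O)Nc4ccc(O)cc43)c(Cl)n(Cc3cc(OC)c(OC)c(OC)c3)c2cc1C`, 1410 nM
compound 3, `O=C1/C(=C/c2c(Cl)[nH]c3ccccc23)c2ccccc2N1Cc1ccccc1`, 2950 nM

In a functional assay on cells (Leukemia cell, Homo sapiens) for cytotoxicity, with a stated time of 48 h (on this read-out lower numbers stand for stronger inhibition of growth and higher numbers for weaker inhibition of growth), compound 2 gives the lowest of the three numbers. Compound 1 sits within the scatter of it, so the two cannot be ordered; compound 3 lies beyond the scatter with the higher number. Compound 4, `COc1cc2c(/C=C3/C(=O)Nc4cccc(Cl)c43)c(Cl)n(Cc3cc(OC)c(OC)c(OC)c3)c2cc1C`, has not been measured in this assay. It differs from compound 2 by a group of 12 heavy atoms (9 carbon, 1 nitrogen, 1 oxygen, 1 chlorine; one five-membered non-aromatic ring with 1 hetero atom, one six-membered aromatic ring of carbon only) in place of a group of 12 heavy atoms (9 carbon, 1 nitrogen, 2 oxygen; one five-membered non-aromatic ring with 1 hetero atom, one six-membered aromatic ring of carbon only), on an aromatic carbon. The entering group brings 1 hydrogen-bond donor and 1 hydrogen-bond acceptor where the leaving group had 2 of each. Within the data shown here, no measured pair shows this change, so its effect is unknown; the expected step of a 1.2-fold higher number from compound 2 to compound 4 (0.08 log units; within the scatter) is none beyond the scatter. Compound 4 is therefore expected near 1700 nM, within 600 nM to 4800 nM.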

Compound 4, concentration for 50% growth inhibition: 2450 nM
Estimate against measurement, compound 4: 1.4-fold (0.16 log units) below; measured number inside the range.
By their numbers in this assay, from the lowest: compounds 2, 1, 4 and 3 (each within the scatter of the next, the first and the last beyond it).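

In this assay, among these compounds, the one comparison across a single place gives a 1.7-fold higher number from compound 2 to compound 4 (0.24 log units; within the scatter) on an aromatic carbon of the five-membered aromatic ring with 1 nitrogen. The group with 1 chlorine, bringing 1 hydrogen-bond donor and 1 hydrogen-bond acceptor, can thus stand in place of the group with 2 oxygen atoms and 2 of each without a change beyond the scatter. No measurement shown offers an explanation for this result. The compounds shown leave open whether an amine or a carboxylic acid on the group at this place would give a step beyond the scatter.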